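Replacing the cyclohexyl of compound 1 with a substituted furan

This account rests on a few compounds, and the source may have more. Where it says the series, first, only, none or still open, it means among the compounds named here.

Measured compounds:
compound 1 `CCCC(=O)N1CCC(NS(=O)(=O)c2ccc(NC(=O)C3CCCCC3)c3ccccc23)CC1`: 6.1 nM
compound 2 `CCCCc1ccc(C(=O)Nc2ccc(S(=O)(=O)NC3CCN(C(=O)CCC)CC3)c3ccccc23)cc1`: 15.3 nM
compound 3 `CCCC(=O)N1CCC(NS(=O)(=O)c2ccc(NC(=O)c3ccoc3)c3ccccc23)CC1`: 1520 nM

In an in vitro functional assay on CHO/Galpha16 cells for antagonist activity at C-C chemokine receptor type 8 (Homo sapiens), read by FLIPR (a lower number here means a stronger inhibitor, a higher number a weaker inhibitor), compound 1 gives 6.1 nM, the lowest number of the three. The other two compounds differ from it only in the group on the carbonyl carbon of the amide. With 4-butylphenyl there, the step is a 2.5-fold higher number from compound 1 to compound 2 (0.40 log units; beyond the scatter). With furan-3-yl there, the step is a 250-fold higher number from compound 1 to compound 3 (2.40 log units; beyond the scatter), a very large loss.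

Compound 4 `CCCC(=O)N1CCC(NS(=O)(=O)c2ccc(NC(=O)c3cc(C)oc3C(F)(F)F)c3ccccc23)CC1` has not yet been measured. It differs from compound 1 in one place: 5-methyl-2-(trifluoromethyl)furan-3-yl in place of cyclohexyl on a carbonyl carbon. The entering ring is the same furan that cost so much in compound 3, but now carrying a methyl and a trifluoromethyl. The step from compound 1 to compound 3 argues for a clearly higher number; the step from compound 1 to compound 2 shows that a non-cyclohexyl group can be tolerated. Going by the values given here, with no measured example of this substituted furan, the expected step is an 8.2-fold higher number from compound 1 to compound 4 (0.91 log units; beyond the scatter), a loss smaller than that of compound 3 but beyond the scatter. Compound 4 is therefore estimated at 50 nM, within 8 nM to 400 nM.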

Compound 4, half-maximal inhibitory concentration: 46.9 nM
For compound 4 the middle estimate is 1.1-fold (0.03 log units) above the measured one; low and high end bracket the measured number.
By their numbers in this assay, from the lowest: compound 1; then compound 2; then compound 4; then compound 3.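

The bare furan ring does not rule out good activity at this position: in this assay, adding a methyl and a trifluoromethyl to it gives a 32-fold lower number from compound 3 to compound 4 (1.51 log units; beyond the scatter) and wins back part of the loss seen with furan-3-yl. The recovery is only partial, since the substituted furan still shows a 7.7-fold higher number from compound 1 to compound 4 (0.89 log units; beyond the scatter) against the cyclohexyl and a 3.1-fold higher number from compound 2 to compound 4 (0.49 log units; beyond the scatter) against the 4-butylphenyl on the same carbonyl carbon. No measurement here explains why the substituted furan does better than the bare one. Which of the two substituents carries the gain stays open: a furan-3-yl bearing only the methyl, or only the trifluoromethyl, would separate them. Also open, on these data alone, is whether a cyclopentyl or a tert-butyl on this carbonyl carbon would match the cyclohexyl.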